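The source may report more compounds than this note shows. Statements on the series, on what has been measured and on what is new or still open speak of the compounds shown alone.

The shared core carries a five-membered aromatic ring with three nitrogens, and the group on one of those nitrogens is what varies. Compound 1 `CCOC(=O)C1=Cc2ccccc2OC1(OCc1cn(-c2ccc(F)cc2)nn1)C(F)(F)F` gives 9100 nM in a functional assay on MCF7 cells (Homo sapiens) for inhibition, read by MTT assay, with a stated time of 24 h; on this read-out lower numbers stand for stronger inhibition and higher numbers for weaker inhibition. Compound 2 `CCOC(=O)C1=Cc2ccccc2OC1(OCc1cn(-c2cccc(OC)c2)nn1)C(F)(F)F` reaches only a limit of this assay, > 150000 nM. Compound 3 `CCOC(=O)C1=Cc2ccccc2OC1(OCc1cn(-c2ccccc2)nn1)C(F)(F)F` likewise gives only a limit in this assay, > 150000 nM. Compound 3 therefore stands at the top edge of what this assay reports, a position it shares with one other compound (the limit of > 150000 nM in this assay, at which 2 of the 3 values shown sit), so its rank among the measured compounds cannot be set more closely.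

Compound 4 `CCOC(=O)C1=Cc2ccccc2OC1(OCc1cn(CC(=O)Nc2ccccc2F)nn1)C(F)(F)F` differs from compound 3 by ((2-fluorophenyl)carbamoyl)methyl in place of phenyl on an aromatic nitrogen. Among the measured compounds shown here, two measured steps touch this change. The step of an at least 16-fold higher number from compound 1 to compound 3 (1.21 log units; beyond the scatter) shows what the loss of fluoro on an aromatic carbon did. The step that the two limits leave unreadable from compound 2 to compound 3 yields no size that can be read. Compound 4 brings a fluoro on an aromatic carbon back, though inside a larger group with an amide linker. A downward step in this assay is therefore expected, estimated at an at least 3.7-fold lower number from compound 3 to compound 4 (0.57 log units; beyond the scatter). Compound 4 is expected to give 40000 nM, with a range from 8000 nM to 150000 nM, and a real chance remains that this assay again returns only a limit.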

Compound 4, half-maximal inhibitory concentration: 42100 nM
For compound 4 the middle estimate is 1.1-fold (0.02 log units) below the measured one, within the range that was stated.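

Among the compounds shown, a phenyl ring sitting directly on the aromatic nitrogen is not needed for a readable number in this assay: the ((2-fluorophenyl)carbamoyl)methyl group, with its amide linker, gives an at least 3.5-fold lower number from compound 3 to compound 4 (0.55 log units; beyond the scatter) and an at least 3.5-fold lower number from compound 2 to compound 4 (0.55 log units; beyond the scatter). This larger group does not reach the level of the 4-fluorophenyl group, however, with a 4.6-fold higher number from compound 1 to compound 4 (0.67 log units; beyond the scatter), so compound 1 keeps the lowest number of the four. Compound 4 thus joins compound 1 with a readable value, while compound 2 and compound 3 remain at the top edge of what the assay reports: the limit of > 150000 nM in this assay, at which 2 of the 4 values shown sit.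

The compounds shown do not separate what the amide linker contributes to the step from what the fluoro on the aromatic ring contributes, as compound 4 changes both at once. They also leave open how this position would read with a longer chain carrying the same amide, with chloro in place of fluoro on the ring, or with a carboxylic acid in place of the anilide.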